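Ethynyl for methyl on the ether chain of compound 1

This account rests on a few compounds, and the source may have more. Where it says the series, first, only, none or still open, it means among the compounds named here.

Measured compounds:
compound 1 `CCOCCn1c(N2CCN(C)CC2)nc2ccccc21` gives 10 nM in a functional assay on ileum for inhibition of histamine H1 receptor (Cavia porcellus); a higher number here means a weaker inhibitor, a lower number a stronger inhibitor
compound 2 `CCOCCn1c(N2CCN(CC)CC2)nc2ccccc21` gives 18 nM in this assay

Compound 1 has the lowest of the two numbers shown; its only neighbour is compound 2, and the step of a 1.8-fold higher number from compound 1 to compound 2 (0.26 log units; within the scatter) lies within the scatter, so the two compounds cannot be ordered. The unmeasured compound 3 `C#CCOCCn1c(N2CCN(C)CC2)nc2ccccc21` differs from compound 1 by ethynyl in place of methyl on a saturated chain carbon bound to an oxygen on a saturated carbon. Among the measured compounds shown here, no measured step touches the ether chain; the single step available, a 1.8-fold higher number from compound 1 to compound 2 (0.26 log units; within the scatter), concerns the amine side of the shared core and is itself within the scatter. Nothing in the data therefore points to a shift in this assay in either direction, and a step no larger than the scatter is expected, a 1.5-fold higher number from compound 1 to compound 3 (0.18 log units; within the scatter). Compound 3 is estimated at 15 nM, with a range from 5 nM to 45 nM.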

Compound 3, half-maximal inhibitory concentration: 12 nM
The estimate for compound 3 lay 1.3-fold (0.10 log units) above the measured number; low and high end bracket the measured number.
By their numbers in this assay, from the lowest: compounds 1, 3 and 2 (each within the scatter of the next).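

The ether chain of compound 1 now has its first reading in this assay, where ethynyl in place of methyl gives a 1.2-fold higher number from compound 1 to compound 3 (0.08 log units; within the scatter) and leaves the two compounds unordered. Among the compounds shown here, the one earlier step concerned only the amine side of the shared core, so this is the first sign that a group with one more heavy atom and a triple bond outside aromatic rings can stand on this chain with the number staying within the scatter of compound 1. Nothing on hand explains this result.

From the compounds shown here alone, whether a longer chain, a hydroxyl group or an amine at this place would also stay within the scatter remains open. So does whether propargyloxy would give the same result on compound 2, which carries ethyl in place of methyl on the amine side.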